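Dropping One Methoxy Group in Two Related Pairs

The compounds below may be only part of what the source reports. "The series", "measured", "known", "first", "only" and "open" are said of these compounds alone.

Compound 1 `COc1cc(-c2cc(/C=C/C(=O)c3ccc(N)cc3)[nH]n2)cc(OC)c1OC` and compound 2 `COc1ccc(-c2cc(/C=C/C(=O)c3ccc(N)cc3)[nH]n2)cc1OC` share one core and differ in a single place: hydrogen in place of methoxy on an aromatic carbon. In a functional assay on 786-0 cells (Homo sapiens) for cytotoxicity, read by sulforhodamine B assay, with a stated time of 48 h, tested at 1 uM (a lower number here means a stronger effect, a higher number a weaker effect of the compound at the concentration tested), compound 1 gives 81%, and compound 2 gives 87%; the step of a number 6 percentage points higher from compound 1 to compound 2 (within the scatter) is small. Compound 3 `COc1cc(C(=O)/C=C/c2cc(-c3cc(OC)c(OC)c(OC)c3)n[nH]2)cc(OC)c1OC` is built on a different core, and the difference between the two cores is not broken down here. In this assay compound 3 gives 80%, a number close to those of compound 1 and compound 2.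

Compound 4 `COc1ccc(-c2cc(/C=C/C(=O)c3cc(OC)c(OC)c(OC)c3)[nH]n2)cc1OC` has not yet been measured. It relates to compound 3 as compound 2 relates to compound 1: hydrogen in place of methoxy on an aromatic carbon. The surroundings of the changed carbon read the same in both pairs, so this is the same change. The earlier step of a number 6 percentage points higher from compound 1 to compound 2 (within the scatter) stayed within the scatter, and a comparably small step is expected here. The expected step is a number 6 percentage points higher from compound 3 to compound 4 (within the scatter). Compound 4 is therefore estimated at 86% in this assay, with a range from 72% to 100%. This rests on a single measured pair only, so the range is kept wide.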

Compound 4, a percentage reported as activity, at one concentration (the size of the read-out at that concentration, not a potency): 81%
Estimate against measurement, compound 4: 5 percentage points above; measured number inside the range.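

Putting hydrogen in place of methoxy on an aromatic carbon gives a number 1 percentage points higher from compound 3 to compound 4 (within the scatter) in this assay. Set beside the earlier pair, the new step does not differ from it, so on both cores this change leaves the read-out within the usual scatter: the same change on two cores in this assay, a number 6 percentage points higher (within the scatter) from compound 1 to compound 2 and a number 1 percentage points higher (within the scatter) from compound 3 to compound 4, 5 percentage points apart, within the scatter of two such steps. This does not show that every change carries over from one core to another in this series, since two pairs make no general rule, and a step that stays within the scatter cannot tell whether a change with a clear effect would carry over in the same way.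

The compounds shown carry only methoxy or hydrogen at this carbon, so what an amine, a hydroxyl group or a longer chain such as propoxy would do there stays open. From the compounds shown here alone, it also remains open whether the step stays this small on a core other than these two.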